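Series notes: isatin-derived acrylates, benzyl substituent swap

The source may hold more compounds than are shown below. What is called first, only, known or untested is meant among the compounds shown, and "the series" means these compounds.

Measured so far:
Compound 1, `COC(=O)/C=C/c1ccc2c(c1)/C(=N/O)C(=O)N2Cc1ccc(Br)cc1`, gives 2920 nM in a functional assay on K562 cells (Homo sapiens) for cytotoxicity, read by MTT assay, with a stated time of 48 h; a higher number here means a weaker inhibitor, a lower number a stronger inhibitor.
Compound 2, `COc1ccc(CN2C(=O)C(=O)c3cc(/C=C/C(=O)OCCO)ccc32)cc1`, gives 40 nM in this assay.
Compound 3, `COC(=O)/C=C/c1ccc2c(c1)/C(=N/O)C(=O)N2Cc1ccc(OC)cc1`, gives 2110 nM in this assay.

Compound 2 sits lowest of the three numbers, and its gaps to compound 3 and compound 1 are both beyond the scatter. How the core of compound 2 differs from the core of compound 3 is not broken down here; the two differ in more than one place.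

Within the pair that shares a core, the single change is bromo in place of methoxy on an aromatic carbon. Its step is a 1.4-fold higher number from compound 3 to compound 1 (0.14 log units; within the scatter), so on that core the swap leaves the number essentially where it was.

Compound 4, `O=C(/C=C/c1ccc2c(c1)C(=O)C(=O)N2Cc1ccc(Br)cc1)OCCO`, is not yet measured. It is related to compound 2 by bromo in place of methoxy on an aromatic carbon, the same change as between compound 3 and compound 1, made on the core of compound 2 instead. Going by the values given here, with only one prior example of this change, and that example within the scatter, the expectation is that compound 4 stays close to compound 2, with a step of about a 1.4-fold higher number from compound 2 to compound 4 (0.14 log units; within the scatter), because compound 3 to compound 1 showed a 1.4-fold higher number from compound 3 to compound 1 (0.14 log units; within the scatter). Compound 4 is therefore estimated at 55 nM in this assay, expected to lie between 20 nM and 160 nM. From the compounds shown here alone, whether the change carries over to the different core of compound 2 is untested, so the range is kept wide.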

Compound 4, half-maximal inhibitory concentration: 50 nM
Estimate against measurement, compound 4: 1.1-fold (0.04 log units) above; the measured number falls inside the stated range.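

In this assay, bromo in place of methoxy on an aromatic carbon of the benzyl group gives a 1.3-fold higher number from compound 2 to compound 4 (0.10 log units; within the scatter), so on this second core, too, the swap leaves the number essentially where it was. The change therefore behaves alike on both cores shown, and the two steps do not differ: the same change on two cores in this assay, a 1.4-fold higher number (0.14 log units; within the scatter) from compound 3 to compound 1 and a 1.3-fold higher number (0.10 log units; within the scatter) from compound 2 to compound 4, 1.1-fold (0.04 log units) apart, within the scatter of two such steps. Going by these compounds alone, this shows only that 4-methoxybenzyl and 4-bromobenzyl are interchangeable within the scatter in this cytotoxicity read-out on these two cores; two pairs give no rule for any further core or for other substituents, and steps this small do not show what either group contributes, only that the exchange between these two leaves no mark on the number.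

Still open, from the compounds shown here alone, is whether a different group in that place, para to a large group, such as an amine, a carboxylic acid or a longer chain, would move the number on either core. Also open is which of the several places where the two cores differ matters for the number, as no pair shown changes one of those places alone.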